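A few compounds are considered here, and "the series" means these few. Any claim that something is new, unique, unknown or untested is made for them only; others in the source may bear on it.

In a functional assay on Jurkat cells (Homo sapiens) (a higher number here means a weaker inhibitor, a lower number a stronger inhibitor), compound 1 `CC(C)[C@H](NC(=O)COc1cccc2ccccc12)C(=O)N[C@@H](CC(=O)O)C(=O)COC(=O)c1c(Cl)cccc1Cl` gives 10600 nM and compound 2 `CC(C)[C@H](NC(=O)COc1cccc2ccccc12)C(=O)N[C@@H](CC(=O)O)C(=O)COc1ccc(OC(F)(F)F)cc1` gives 29100 nM as the higher of the two numbers, which makes compound 2 the weaker inhibitor of this pair. Compound 3 `CC(=O)Nc1cccc(OCC(=O)[C@H](CC(=O)O)NC(=O)[C@@H](NC(=O)COc2cccc3ccccc23)C(C)C)c1` keeps the shared core and changes one group 3-acetamidophenyl in place of 4-(trifluoromethoxy)phenyl on an oxygen on a saturated carbon so that 3-acetamidophenyl stands in place of 4-(trifluoromethoxy)phenyl on an oxygen on a saturated carbon. Among the compounds with values here, the one measured step at that place is a 2.7-fold higher number from compound 1 to compound 2 (0.44 log units; beyond the scatter) and it exchanged a different pair of groups, so it offers a rough size but no direction. No step beyond the scatter is therefore the likeliest expectation in this assay for this change, although a modest step either way would be unsurprising. That expectation amounts to a 1.2-fold lower number from compound 2 to compound 3 (0.07 log units; within the scatter) as the estimated step. Compound 3 is estimated at 25000 nM with an expected range from 8000 nM to 70000 nM around that value.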

Compound 3, half-maximal inhibitory concentration: > 100000 nM
Compound 3: a limit, no number; the forecaster's own chance of this, stated with the estimate: 15%; middle value at least 4.0-fold (0.60 log units) from the limit.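

In this assay, the reading for compound 3 is a limit and not a number: the limit of > 100000 nM in this assay, at which 1 of the 3 values shown sits. Placing 3-acetamidophenyl on this oxygen gives an at least 3.4-fold higher number from compound 2 to compound 3 (0.53 log units; beyond the scatter), and the comparison with the ester-linked group of the first compound gives an at least 9.4-fold higher number from compound 1 to compound 3 (0.97 log units; beyond the scatter). Within the data shown here, this position can therefore tolerate less than the single earlier step suggested, and both new steps are only minimum sizes, so the true loss of inhibition may be larger.

The compounds shown do not separate the effect of the acetamide group from the effect of where it sits, or from the loss of the trifluoromethoxy group. As far as these compounds go, whether a plain phenyl or a 4-acetamidophenyl on this oxygen would read closer to compound 2 or to compound 3 remains open.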